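Ethylsulfanyl for hydroxy on the amine-bearing chain

This account rests on a few compounds, and the source may have more. Where it says the series, first, only, none or still open, it means among the compounds named here.

Among the compounds with values here, compound 1 `CSCC[C@H](NC(=O)c1ccc(CN[C@H](CO)CC2CCCCC2)cc1-c1ccccc1C)C(=O)O` is the only compound of the pair with a number in a functional assay for inhibition, with Rattus norvegicus as the target; on this read-out lower numbers stand for an effect already at smaller amounts and higher numbers for an effect only at larger amounts of compound; in this assay compound 1 gives 190 nM. Compound 2 `CSCC[C@H](NC(=O)c1ccc(CN(CCC2CCCCC2)C(C)=O)cc1-c1ccccc1C)C(=O)O` reaches only the limit of the assay, > 1000 nM, and this assay reports no number for compound 2 (the limit of > 1000 nM in this assay, at which 1 of the 2 values shown sits). Within the data shown here, the one measured step, an at least 5.2-fold higher number from compound 1 to compound 2 (0.72 log units; beyond the scatter), changes the same saturated chain carbon bound to an aromatic carbon that is altered here, though with a different group.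

Compound 3 `CCSC[C@H](CC1CCCCC1)NCc1ccc(C(=O)N[C@@H](CCSC)C(=O)O)c(-c2ccccc2C)c1` differs from compound 1 by ethylsulfanyl in place of hydroxy on a saturated chain carbon, two bonds along the chain from an amine nitrogen. Among the measured compounds shown here, only the step from compound 1 to compound 2 bears on this change, and it was at least modest and in the weakening direction. A smaller shift is expected here, since the amine itself is kept; the estimated step is a 2.2-fold higher number from compound 1 to compound 3 (0.34 log units; beyond the scatter), a modest rise in this assay. For compound 3 the expected value in this assay is 420 nM, within 150 nM to 1400 nM.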

Compound 3, half-maximal effective concentration: 4.4 nM
For compound 3 the middle estimate is 95-fold (1.98 log units) above the measured one; the measured number lies below the stated range.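

The chain carbon two bonds along from the amine nitrogen is far more sensitive to substitution than the earlier pair could show: in this assay, ethylsulfanyl in place of hydroxy gives a 43-fold lower number from compound 1 to compound 3 (1.64 log units; beyond the scatter). The hydroxy is therefore not needed for a low number in this series, as compound 3 carries no hydrogen-bond donor in the entering group yet stands well beyond the scatter from compound 1, with the amine and the rest of the structure kept. Nothing measured here accounts for this gain.

Open, going by these compounds, is whether the step follows the sulfur or the added carbons, a question that ethoxy, methylsulfanyl or propylsulfanyl on the same carbon would address. Also open, on these data alone, is how an amine or a carboxylic acid at this place would read in this assay.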